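The source may hold more compounds than are shown below. What is called first, only, known or untested is meant among the compounds shown, and "the series" means these compounds.

Measured in a physicochemical assay for solubility, read by nephelometry, measured as kinetic solubility, at pH 6.5; a lower number here means a less soluble compound, a higher number a more soluble compound:
- compound 1 `CC(C)Oc1ccc(C(O)(c2ccc(Cl)cc2)c2cccnc2)cc1`: 1.6 ug/mL
- compound 2 `NC(=O)c1cccc(C(O)(c2cccnc2)c2ccc(Cl)cc2F)c1`: 50 ug/mL

Compound 1 has the lower of these two numbers, and the gap to compound 2 lies beyond the usual scatter. Compound 3 `CC(C)Oc1ccc(C(O)(c2cccnc2)c2ccc(Cl)cc2F)cc1` keeps the core of compound 1 and changes one place: fluoro in place of hydrogen on an aromatic carbon. For the measured compounds named here, compound 2 carries the same 4-chloro-2-fluorophenyl group and gives 50 ug/mL, but it also differs elsewhere, so no measured pair isolates this change. The estimated 1.1-fold higher number from compound 1 to compound 3 (0.05 log units; within the scatter) stays within the scatter in this assay, with no clear direction expected. For compound 3 the expected value is 1.8 ug/mL, with an estimated range of 0.7 ug/mL to 4.5 ug/mL.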

Compound 3, solubility: 1.6 ug/mL
Estimate against measurement, compound 3: 1.1-fold (0.05 log units) above, within the range that was stated.
By their numbers in this assay, from the lowest: compounds 1 and 3 (each within the scatter of the next); then compound 2.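

In this assay the step reads no change at the digits printed from compound 1 to compound 3 (within the scatter) when fluoro replaces hydrogen on the aromatic carbon, turning 4-chlorophenyl into 4-chloro-2-fluorophenyl. This pair isolates that single change, which compound 2 could not do, since it also differs elsewhere. Nothing measured here offers a reason for this result.

On these data alone, it remains open whether another group at this place, such as methoxy or an amine, would shift the number. Also open, as far as these compounds go, is whether fluoro would read the same alongside the amide group of compound 2.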